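This account rests on a few compounds, and the source may have more. Where it says the series, first, only, none or still open, it means among the compounds named here.

Compound 1 `Cc1ccc(NC(=S)NC(=O)c2ccc(OCc3ccccc3)cc2)cc1-c1nc2ccccc2[nH]1` and compound 3 `Cc1ccc(NC(=O)NC(=O)c2ccc(OCc3ccccc3)cc2)cc1-c1nc2ccccc2[nH]1` share a core whose difference is not broken down here; the two are simply treated as distinct cores. Compound 1 was tested in a functional assay on HT-29 cells (Homo sapiens) for inhibition, read by MTT assay, with a stated time of 48 h (a higher number here means a weaker inhibitor, a lower number a stronger inhibitor), and gave 28800 nM. Compound 3, tested in this assay, gave 16400 nM, which is a smaller number than that of compound 1 but stays within the scatter of this kind of measurement, so no order between the two is claimed.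

Compound 2 `Cc1ccc(NC(=S)NC(=O)c2ccc(OCc3cccc(Cl)c3)cc2)cc1-c1nc2ccccc2[nH]1` carries on the core of compound 1 the change (chloro in place of hydrogen on an aromatic carbon). In this assay compound 2 gave 35300 nM, so the step was a 1.2-fold higher number from compound 1 to compound 2 (0.09 log units; within the scatter), a movement too small to be read as a change.

Compound 4 `Cc1ccc(NC(=O)NC(=O)c2ccc(OCc3cccc(Cl)c3)cc2)cc1-c1nc2ccccc2[nH]1` has not yet been measured. It arises from compound 3 by chloro in place of hydrogen on an aromatic carbon, which is the same change as that from compound 1 to compound 2, placed in the same way. Going by the values given here, the expectation for compound 4 rests on a single precedent, the step from compound 1 to compound 2; with only one earlier instance, the estimate is expected to carry a broad range. Compound 4 is estimated to show a step of a 1.2-fold higher number from compound 3 to compound 4 (0.09 log units; within the scatter) in this assay, because the earlier step of a 1.2-fold higher number from compound 1 to compound 2 (0.09 log units; within the scatter) stayed within the scatter. Compound 4 is therefore expected to give about 20000 nM in this assay, with the plausible interval estimated to run from 9000 nM to 45000 nM.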

Compound 4, half-maximal inhibitory concentration: 15400 nM
The estimate for compound 4 lay 1.3-fold (0.11 log units) above the measured number; the range from low to high includes it.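

In this assay, putting chloro in place of hydrogen on the core of compound 3, which turns benzyl into 3-chlorobenzyl, gave a 1.1-fold lower number from compound 3 to compound 4 (0.03 log units; within the scatter), a movement too small to be read as a change. Set beside the earlier step, the result gives no sign that the two cores respond differently to this change: the same change on two cores in this assay, a 1.2-fold higher number (0.09 log units; within the scatter) from compound 1 to compound 2 and a 1.1-fold lower number (0.03 log units; within the scatter) from compound 3 to compound 4, 1.3-fold (0.12 log units) apart, within the scatter of two such steps. This shows that, in these two pairs, the chloro left the number unchanged within the scatter on either core, so the flat result carried over from one core to the other, but it does not show that any measurable effect transfers, since neither step gave an effect large enough to carry, and two pairs cannot establish a rule for the wider series.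

The compounds shown leave open whether a different group in the same place on the benzyl ring, such as fluoro, methoxy, nitrile or an amine, would move the number beyond the scatter on either core. They also leave open whether replacing the whole benzyloxy group with a longer chain or a carboxylic acid would do so.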